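The source may report more compounds than this note shows. Statements on the series, on what has been measured and on what is new or still open speak of the compounds shown alone.

Working notes on the series. Among the compounds with values here, compound 2 `CCOC(=O)c1cc(-c2ccccc2)nn1CC(O)COc1ccc(Cl)cc1` stands second highest of the three numbers so far: in a functional assay on A549 cells (Homo sapiens) for inhibition, read by MTT assay, with a stated time of 48 h (a higher number here means a weaker inhibitor, a lower number a stronger inhibitor), compound 2 gives 59000 nM. Its nearest neighbour is compound 1 `CCOC(=O)c1cc(-c2ccccc2)nn1CC(O)COc1ccccc1`, which in this assay gives 65000 nM, and the furthest is compound 3 `CCOC(=O)c1cc(-c2ccccc2)nn1CC(O)COc1ccccc1[N+](=O)[O-]`, which in this assay gives 30000 nM. The step of a 1.1-fold lower number from compound 1 to compound 2 (0.04 log units; within the scatter) and the step of a 2.0-fold lower number from compound 2 to compound 3 (0.29 log units; within the scatter) both fall within the scatter, while a 2.2-fold lower number from compound 1 to compound 3 (0.34 log units; beyond the scatter) is a modest step beyond it.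

Compound 4 `CCOC(=O)c1cc(-c2ccc(OC)cc2)nn1CC(O)COc1ccc(Cl)cc1` differs from compound 2 by methoxy in place of hydrogen on an aromatic carbon. Within the data shown here, no measured step touches this ring; the three measured steps all concern the other ring, and the two that change one substituent to another there, a 1.1-fold lower number from compound 1 to compound 2 (0.04 log units; within the scatter) and a 2.2-fold lower number from compound 1 to compound 3 (0.34 log units; beyond the scatter), are small. With no comparable change on record, the estimate is a step of a 1.2-fold lower number from compound 2 to compound 4 (0.07 log units; within the scatter), that is none beyond the scatter. Compound 4 is therefore expected to give about 50000 nM in this assay, with a range from 22000 nM to 110000 nM.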

Compound 4, half-maximal inhibitory concentration: 38000 nM
The estimate for compound 4 lay 1.3-fold (0.12 log units) above the measured number, and the stated range covers the measured number.
By their numbers in this assay, from the lowest: compounds 3, 4, 2 and 1 (each within the scatter of the next, the first and the last beyond it).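

Phenyl to 4-methoxyphenyl is the first change shown on this side of the molecule, and in this assay it gives a 1.6-fold lower number from compound 2 to compound 4 (0.19 log units; within the scatter). The two values stand within the scatter of each other, so methoxy on this aromatic carbon, para to a large group, is compatible with the level of compound 2 but cannot be read as a gain. Nothing available accounts for the size of this step.

Going by these compounds, whether another group on this carbon, such as an amine, a carboxylic acid or a longer alkoxy chain, would give a step beyond the scatter remains open. On these data alone, it is also open whether 4-methoxyphenyl would give a similar step with the unsubstituted phenoxy group of compound 1 or the 2-nitrophenyl group of compound 3.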